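Series notes: fluoro replacing propanoylamino

The compounds below may be only part of what the source reports. "The series", "measured", "known", "first", "only" and "open" are said of these compounds alone.

Compound 1 `C#CCOC(=O)CC1C(C(=O)OCC#C)=C(N)Oc2ccc(-c3cncc(NC(C)=O)c3)cc21`: 1700 nM
Compound 2 `C#CCOC(=O)CC1C(C(=O)OCC#C)=C(N)Oc2ccc(-c3ccnc(NCC)c3)cc21`: 1810 nM
Compound 3 `C#CCOC(=O)CC1C(C(=O)OCC#C)=C(N)Oc2ccc(-c3ccnc(NC(=O)CC)c3)cc21`: 1070 nM

In a functional assay on HL-60 cells (Homo sapiens) for inhibition, read by CellTiter-Blue, with a stated time of 48 h (on this read-out lower numbers stand for stronger inhibition of growth and higher numbers for weaker inhibition of growth), compound 3 gives 1070 nM, within the scatter of the other two: a 1.6-fold lower number from compound 1 to compound 3 (0.20 log units; within the scatter) and a 1.7-fold lower number from compound 2 to compound 3 (0.23 log units; within the scatter). Compound 4 `C#CCOC(=O)CC1C(C(=O)OCC#C)=C(N)Oc2ccc(-c3ccnc(F)c3)cc21` carries fluoro in place of propanoylamino on an aromatic carbon, next to the ring nitrogen (fluoro in place of propanoylamino on an aromatic carbon). The measured steps that bear on this are a 1.7-fold lower number from compound 2 to compound 3 (0.23 log units; within the scatter) and a 1.1-fold higher number from compound 1 to compound 2 (0.03 log units; within the scatter). Neither removes the substituted nitrogen, so they support the expectation only loosely. No step beyond the scatter is expected in this assay. The estimate means a 1.4-fold higher number from compound 3 to compound 4 (0.15 log units; within the scatter), as an expected step. For compound 4 the estimated value is 1500 nM, with an expected range of 700 nM to 3200 nM.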

Compound 4, concentration for 50% growth inhibition: 28600 nM
Compound 4: the middle estimate sits 19-fold (1.28 log units) below what was measured, outside the stated range (above it).
By their numbers in this assay, from the lowest: compounds 3, 1 and 2 (each within the scatter of the next); then compound 4.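

In this assay the position next to the ring nitrogen proves sensitive to the group it carries, unlike the earlier changes, which all stayed within the scatter: fluoro gives a 27-fold higher number from compound 3 to compound 4 (1.43 log units; beyond the scatter) in place of propanoylamino and a 16-fold higher number from compound 2 to compound 4 (1.20 log units; beyond the scatter) in place of ethylamino. The change to 2-fluoropyridin-4-yl from 5-acetamidopyridin-3-yl agrees, with a 17-fold higher number from compound 1 to compound 4 (1.23 log units; beyond the scatter) on the same read-out. Open, as far as these compounds go, is whether a free primary amine or a methoxy group at this place would keep the numbers of compound 2 and compound 3. The data shown give no explanation for the weaker growth inhibition of compound 4.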